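Compound 3 to compound 4: adding methoxy to the phenyl ketone

The compounds below may be only part of what the source reports. "The series", "measured", "known", "first", "only" and "open" are said of these compounds alone.

In an ADME assay on MT4 cells (Homo sapiens) for cytotoxicity, read by MTT assay (a lower number here means that less compound is tolerated, a higher number that more compound is tolerated), compound 3 `CCc1c(Cc2c(F)cccc2Cl)nc(SCC(=O)c2ccccc2)[nH]c1=O` gives only a limit, > 12000 nM, and no exact number is available for it. Compound 3 stands at the limit of > 12000 nM in this assay, at which 2 of the 3 values shown sit. Compound 2 `COc1ccc(C(=O)CSc2nc(Cc3c(F)cccc3Cl)cc(=O)[nH]2)cc1`, which carries 4-methoxyphenyl, also gives only a limit, > 12000 nM. Compound 1 `CCc1c(Cc2c(Cl)cccc2Cl)nc(SCC(=O)c2ccc(OC)cc2)[nH]c1=O`, also with 4-methoxyphenyl, gives only a limit, > 54000 nM. Compound 4 `CCc1c(Cc2c(F)cccc2Cl)nc(SCC(=O)c2ccc(OC)cc2)[nH]c1=O` changes phenyl to 4-methoxyphenyl, with methoxy in place of hydrogen on an aromatic carbon. Going by the values given here, no measured pair isolates this change, so no shift beyond the usual scatter is expected in this assay. The expected result is a step that the limit leaves unreadable from compound 3 to compound 4. For compound 4 the estimate is 20000 nM, with an expected range of 10000 nM to 60000 nM.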

Compound 4, half-maximal cytotoxic concentration: > 11000 nM
Compound 4 gave a limit, no number; the forecaster's own chance of this, stated with the estimate: 85%; the middle value is on the limit's open side.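

In this assay, going by these compounds alone, compound 4 gives only a limit, as do compound 1, compound 2 and compound 3, so no step to compound 4 can be read. The compounds shown leave open where the actual cytotoxic concentration of each lies.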